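The source may hold more compounds than are shown below. What is called first, only, known or untested is meant among the compounds shown, and "the series" means these compounds.

The measured compounds:

compound 1, `Oc1ccc(-c2cc(-c3ccc(F)cc3)cc(-c3ccccc3O)n2)cc1`, > 50000 nM
compound 2, `Oc1ccccc1-c1cc(-c2cccc(C(F)(F)F)c2)cc(-c2ccccc2O)n1`, > 50000 nM
compound 3, `Oc1cccc(-c2cc(-c3cccc(C(F)(F)F)c3)cc(-c3ccccc3O)n2)c1`, 6460 nM

In a functional assay on HCT-15 cells (Homo sapiens) for inhibition (on this read-out higher numbers stand for weaker inhibition and lower numbers for stronger inhibition), compound 1 reaches only a limit of the assay, > 50000 nM. Compound 2 likewise gives only a limit, > 50000 nM. Among the compounds with values here, compound 3 is the one compound of the three with a true number, 6460 nM, so it stands as the only measured point of inhibition here.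

The step to compound 4, `Oc1ccc(-c2cc(-c3cccc(C(F)(F)F)c3)cc(-c3ccccc3O)n2)cc1`, is 4-hydroxyphenyl in place of 3-hydroxyphenyl on an aromatic carbon. Within the data shown here, the one measured step that moves a hydroxyphenyl group at this place is an at least 7.7-fold lower number from compound 2 to compound 3 (0.88 log units; beyond the scatter), and it shows how sharply the position of the hydroxyl on that ring can shift the read-out. Compound 1 also carries a 4-hydroxyphenyl group and sits at the limit, which fits (the limit of > 50000 nM in this assay, at which 2 of the 3 values shown sit), though it differs from compound 4 in another group too. A weakening is therefore expected for compound 4, as a 4.6-fold higher number from compound 3 to compound 4 (0.67 log units; beyond the scatter), with a fair chance that only a limit is reported. The expected value for compound 4 is 30000 nM, between 6000 nM and 100000 nM.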

Compound 4, half-maximal inhibitory concentration: > 50000 nM
Compound 4 ended at the assay's limit; the forecaster's own chance of this, stated with the estimate: 45%; at least 1.6-fold (0.22 log units) between middle value and limit.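

In this assay, exchanging the 3-hydroxyphenyl group next to the ring nitrogen for a 4-hydroxyphenyl group gives an at least 7.7-fold higher number from compound 3 to compound 4 (0.88 log units; beyond the scatter). Together with an at least 7.7-fold lower number from compound 2 to compound 3 (0.88 log units; beyond the scatter), this shows that, with the rest of the molecule unchanged, both the 2-hydroxyphenyl and the 4-hydroxyphenyl groups give weaker inhibition than the 3-hydroxyphenyl group, even though all three hold the same atoms. The steps to compound 4 from compound 1 and from compound 2 cannot be read, and limits now make up most of this small set: the limit of > 50000 nM in this assay, at which 3 of the 4 values shown sit.

The 2-hydroxyphenyl and 4-hydroxyphenyl groups cannot be ranked against each other. Also open, going by these compounds, is whether a 3-aminophenyl or 3-methoxyphenyl group at this place would match or improve on the inhibition seen with the 3-hydroxyphenyl group.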